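Hydroxy for Methoxy on the Carbonyl-Side Ring

The source may hold more compounds than are shown below. What is called first, only, known or untested is meant among the compounds shown, and "the series" means these compounds.

Compound 1 `COc1cccc(/C=C/C(=O)c2c(OC)cc(OC)cc2OC)c1` is tested in a functional assay on MDA-MB-231 cells (Homo sapiens), read by fluorescence and BrdU incorporation, with a stated time of 48 h, tested at 10 uM (on this read-out higher numbers stand for a weaker effect at the one concentration tested and lower numbers for a stronger effect), where compound 1 gives 43%. Compound 3 `COc1cc(OC)c(C(=O)/C=C/c2ccc(F)cc2)c(OC)c1` gives 43%, level with compound 1, and compound 2 `COc1cc(OC)c(C(=O)/C=C/c2ccc(Cl)cc2)c(OC)c1` gives 39%. The three stand together: a number 4 percentage points lower from compound 1 to compound 2 (within the scatter), no change at the digits printed from compound 1 to compound 3 (within the scatter) and a number 4 percentage points higher from compound 2 to compound 3 (within the scatter). Compound 4 `COc1cccc(/C=C/C(=O)c2c(O)cc(OC)cc2OC)c1` differs from compound 1 by hydrogen in place of methyl on an oxygen on an aromatic ring. Within the data shown here, every measured step swaps the aryl group on the double-bonded chain carbon or a halogen on that aryl ring; none touches an oxygen on an aromatic ring, so no measured step bears on this change. Lacking such a precedent, the expected step of no change at the digits printed from compound 1 to compound 4 (within the scatter) is small, with no direction favoured. Compound 4 is therefore estimated at 43%, between 25% and 62%.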

Compound 4, a percentage reported as activity, at one concentration (the size of the read-out at that concentration, not a potency): 54%
The estimate for compound 4 lay 11 percentage points below the measured number; the range from low to high includes it.
By their numbers in this assay, from the lowest: compounds 2, 1 and 3 (each within the scatter of the next); then compound 4.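

In this assay the change from methoxy to hydroxy on an oxygen on an aromatic ring brings a number 11 percentage points higher from compound 1 to compound 4 (beyond the scatter) and so a weaker effect at the one concentration tested. This is the first step shown to lie beyond the scatter, so this place affects the read-out, whereas the swaps of aryl group and halogen stayed within it. No measured evidence accounts for the shift. From the compounds shown here alone, what an ethoxy group or an amine at this place would give remains open, as does whether hydroxy for methoxy at the other methoxy groups would give a similar step.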